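Nitro to Cyano on the Aryl Ring: Compound 4

The source may report more compounds than this note shows. Statements on the series, on what has been measured and on what is new or still open speak of the compounds shown alone.

Three compounds have been measured in a functional assay (muscle tissue) with Cavia porcellus as the target; a higher number here means that more compound is needed for the effect, a lower number that less compound is needed:

Compound 1 `COC(=O)C1=C(C)N=C(C)/C(=C(\O)OC)C1c1ccc(Cl)cc1` gives 8130 nM.
Compound 2 `COC(=O)C1=C(C)N=C(C)/C(=C(\O)OC)C1c1ccc(Cl)cc1Cl` gives 640 nM.
Compound 3 `COC(=O)C1=C(C)N=C(C)/C(=C(\O)OC)C1c1cccc([N+](=O)[O-])c1` gives 3.98 nM.

Compound 3 stands lowest of the three; compound 2 and compound 1 both give higher numbers, and both gaps lie beyond the usual scatter. Compound 4 `COC(=O)C1=C(C)N=C(C)/C(=C(\O)OC)C1c1cccc(C#N)c1` is the next compound, and it differs from compound 3 in one place: cyano in place of nitro on an aromatic carbon.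

Going by the values given here, only one measured step is available, a 13-fold lower number from compound 1 to compound 2 (1.10 log units; beyond the scatter). It concerns chloro in place of hydrogen on the aryl ring of compound 1, not nitro or cyano, so it says little about the present change. Among the compounds with values here, no measured pair shows what cyano in place of nitro does here. The expectation therefore rests on compound 3 alone, with a modest rise in the number allowed for the smaller group: the expected step is a 3.8-fold higher number from compound 3 to compound 4 (0.58 log units; beyond the scatter). Compound 4 is thus estimated at 15 nM, within a range from 3 nM to 60 nM.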

Compound 4, half-maximal effective concentration: 34.7 nM
Compound 4: the middle estimate sits 2.3-fold (0.36 log units) below what was measured, and the stated range covers the measured number.
By their numbers in this assay, from the lowest: compound 3; then compound 4; then compound 2; then compound 1.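

In this assay, going by these compounds alone, cyano in place of nitro on this aromatic carbon gives an 8.7-fold higher number from compound 3 to compound 4 (0.94 log units; beyond the scatter) and is the first measured change at this position, showing that the number depends on which of these two groups sits there. The low number is not tied to nitro alone, since 3-cyanophenyl in place of 2,4-dichlorophenyl gives an 18-fold lower number from compound 2 to compound 4 (1.27 log units; beyond the scatter) and 3-cyanophenyl in place of 4-chlorophenyl gives a 230-fold lower number from compound 1 to compound 4 (2.37 log units; beyond the scatter) as well. Nothing available explains why nitro and cyano differ here.

The compounds shown leave open how an amine or a carboxylic acid on this aromatic carbon would compare with nitro and cyano. Also open, on these data alone, is what chloro would give at this same place, as the chlorinated compounds differ from compound 4 in more than that one group.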